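From 4-nitrophenyl to 3-fluorophenyl on the amide nitrogen

The compounds below may be only part of what the source reports. "The series", "measured", "known", "first", "only" and "open" are said of these compounds alone.

Measured in an ADME assay on MT4 cells (Homo sapiens) for cytotoxicity, read by MTT assay, with a stated time of 5 days; a higher number here means that more compound is tolerated, a lower number that less compound is tolerated:
Compound 1 `COc1cc2nc(SCC(=O)Nc3cccc(Cl)c3)nc(Nc3c(Cl)cc(/C=C/C#N)cc3Cl)c2cc1OC`: > 208000 nM (a limit of the assay, not a number)
Compound 2 `COc1cc2nc([S+]([O-])CC(=O)Nc3ccc([N+](=O)[O-])cc3)nc(Nc3c(C)cc(/C=C/C#N)cc3C)c2cc1OC`: 189000 nM
Compound 3 `COc1cc2nc([S+]([O-])CC(=O)Nc3ccc([N+](=O)[O-])cc3)nc(Nc3c(Cl)cc(/C=C/C#N)cc3Cl)c2cc1OC`: 92800 nM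

Of the two true numbers here, the lower belongs to compound 3, at 92800 nM. For the measured compounds named here, the only measured step linking two numbers is a 2.0-fold lower number from compound 2 to compound 3 (0.31 log units; beyond the scatter), which is modest. That step changes a group on a nitrogen on an aromatic ring, not the group at issue now.

The next compound is compound 4 `COc1cc2nc([S+]([O-])CC(=O)Nc3cccc(F)c3)nc(Nc3c(Cl)cc(/C=C/C#N)cc3Cl)c2cc1OC`. It differs from compound 3 in one group, with 3-fluorophenyl in place of 4-nitrophenyl on an amide-type nitrogen.

Going by the values given here, no measured step touches this group, so the data give no direct size for the change. Compound 1 also lacks the 4-nitrophenyl group, and its > 208000 nM is a limit. It differs from compound 3 in other places too, so it offers only a weak hint. Among the compounds with values here, a modest step towards a higher number is therefore expected in this assay, similar in size to the one measured step, and it may not clear the scatter. The estimated change is a 1.5-fold higher number from compound 3 to compound 4 (0.18 log units; within the scatter). Compound 4 is expected at 140000 nM, with an estimated range from 60000 nM to 260000 nM.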

Compound 4, half-maximal cytotoxic concentration: 9550 nM
For compound 4 the middle estimate is 15-fold (1.17 log units) above the measured one, and the stated range ends above it.
By their numbers in this assay, from the lowest: compound 4; then compound 3; then compound 2. At a limit, above all of these: compound 1.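

In this assay, the group on the amide-type nitrogen clearly matters to how much compound the cells tolerate: a 9.7-fold lower number from compound 3 to compound 4 (0.99 log units; beyond the scatter). For the compounds shown here, this is the first measured change at this position, and it shows that swapping 4-nitrophenyl for 3-fluorophenyl moves the number towards less compound tolerated, not more. The only other measured change, a group on a nitrogen on an aromatic ring, gives a 2.0-fold lower number from compound 2 to compound 3 (0.31 log units; beyond the scatter), so among the two steps shown, the one at the amide-type nitrogen is the larger.

With only these two groups compared at this position, the data cannot separate what the loss of the nitro group does from what the gain of the fluorine does, and a plain phenyl group on the same nitrogen would be the natural way to pull the two apart. Compound 1 also lacks the 4-nitrophenyl group, but it differs from compound 4 in more than one place and gives a limit of the assay rather than a number, so it cannot settle the question: the limit of > 208000 nM in this assay, at which 1 of the 4 values shown sits.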